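A few compounds are considered here, and "the series" means these few. Any claim that something is new, unique, unknown or untested is made for them only; others in the source may bear on it.

Measured so far in a functional assay on NCI-H460 cells (Homo sapiens) for cytotoxicity, read by MTT assay, with a stated time of 72 h; a higher number here means a weaker inhibitor, a lower number a stronger inhibitor:
compound 1 `CN(C)CCn1cnnc1-c1cc(Oc2ccc(NC(=O)N/N=C/c3ccc(O)c(Br)c3)cc2F)ccn1` gives 430 nM
compound 2 `CN(C)CCn1cnnc1-c1cc(Oc2ccc(NC(=O)N/N=C/c3ccccc3O[N+](=O)[O-])cc2F)ccn1` gives 1270 nM
compound 3 `CN(C)CCn1cnnc1-c1cc(Oc2ccc(NC(=O)N/N=C/c3c(O)ccc4ccccc34)cc2F)ccn1` gives 890 nM

Compound 3 holds the second highest of the three numbers; the step of a 1.4-fold lower number from compound 2 to compound 3 (0.15 log units; within the scatter) stays within the scatter, while the step of a 2.1-fold higher number from compound 1 to compound 3 (0.32 log units; beyond the scatter) lies beyond it. Compound 4 `CN(C)CCn1cnnc1-c1cc(Oc2ccc(NC(=O)N/N=C/c3ccc(Cl)cc3)cc2F)ccn1` differs from compound 3 by 4-chlorophenyl in place of 2-hydroxynaphthalen-1-yl on a carbon with a double bond to nitrogen. Every earlier change swapped the group at this same carbon: a 3.0-fold higher number from compound 1 to compound 2 (0.47 log units; beyond the scatter) and a 2.1-fold higher number from compound 1 to compound 3 (0.32 log units; beyond the scatter) were both modest. None of them involved 4-chlorophenyl, so the direction cannot be read from the numbers. Compound 4 is therefore expected to give 1000 nM in this assay, most likely between 400 nM and 2500 nM. That estimate means an expected step of a 1.1-fold higher number from compound 3 to compound 4 (0.05 log units; within the scatter), probably within the scatter.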

Compound 4, half-maximal inhibitory concentration: 320 nM
Compound 4: middle estimate off by 3.1-fold (0.49 log units), on the high side; measured number outside the range, below it.
By their numbers in this assay, from the lowest: compounds 4 and 1 (each within the scatter of the next); then compounds 3 and 2 (each within the scatter of the next).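

In this assay, 4-chlorophenyl brings the first clear falls in the number at this carbon: replacing 2-hydroxynaphthalen-1-yl gives a 2.8-fold lower number from compound 3 to compound 4 (0.44 log units; beyond the scatter), and replacing 2-(nitrooxy)phenyl gives a 4.0-fold lower number from compound 2 to compound 4 (0.60 log units; beyond the scatter). Against 3-bromo-4-hydroxyphenyl the change gives a 1.3-fold lower number from compound 1 to compound 4 (0.13 log units; within the scatter), so a hydroxy group on the ring is not needed to reach the level of compound 1. Nothing available explains these differences. Still open, going by these compounds, is what a plain phenyl would give, or an amine or a carboxylic acid in place of the chlorine.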